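A few compounds are considered here, and "the series" means these few. Any claim that something is new, unique, unknown or untested is made for them only; others in the source may bear on it.

In a functional assay on K562 cells (Homo sapiens) for antiproliferative activity, read by MTT assay, with a stated time of 24 h (a lower number here means a stronger inhibitor, a higher number a weaker inhibitor), compound 1 `COc1ccc(C(=O)/C=C/c2cc(OC)c(OC)c(OC)c2)c2c1C=CC(C)(C)O2` gives > 10000 nM as a limit of the assay, not a number. Compound 2 `COc1ccc(C(=O)/C=C/c2ccc(N(C)C)cc2)c2c1C=CC(C)(C)O2` gives 3500 nM and compound 3 `COc1ccc(C(=O)/C=C/c2ccc3ccccc3c2)c2c1C=CC(C)(C)O2` gives 3670 nM in a level pair, their two numbers lying within the scatter of repeated measurements. Compound 4 `COc1ccc(C(=O)/C=C/c2ccccc2)c2c1C=CC(C)(C)O2` differs from compound 2 by hydrogen in place of dimethylamino on an aromatic carbon with hydrogen in place of dimethylamino on an aromatic carbon, para to a large group. Within the data shown here, no measured pair shows this change alone. Compound 3 also lacks dimethylamino yet gives 3670 nM in this test, which argues against a large loss. The expected change, a 1.7-fold higher number from compound 2 to compound 4 (0.23 log units; within the scatter) by estimate, is a moderate move toward a higher number, meaning a weaker inhibitor. For compound 4 the expected value is 6000 nM with an estimated range of 2000 nM to 18000 nM around it.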

Compound 4, half-maximal inhibitory concentration: > 10000 nM
Compound 4 ended at the assay's limit; the forecaster's own chance of this, stated with the estimate: 25%; at least 1.6-fold (0.22 log units) between middle value and limit.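

Replacing dimethylamino with hydrogen on this aromatic carbon, para to a large group, gives in this assay an at least 2.8-fold higher number from compound 2 to compound 4 (0.45 log units; beyond the scatter). Among these compounds, this is the first single-change comparison, and it shows that the group at this position matters for activity on these cells. The step can only be read as a minimum, because compound 4 stands at a limit rather than at a number: the limit of > 10000 nM in this assay, at which 2 of the 4 values shown sit.

The compounds shown leave open how a primary amine or a carboxylic acid at this position would compare with dimethylamino.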